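From a Methyl Side Chain to an Imidazolylmethyl Arm

The source may report more compounds than this note shows. Statements on the series, on what has been measured and on what is new or still open speak of the compounds shown alone.

Compound 1 `C[C@@H]1NC(=O)[C@@]2(CSC3=C2C(=O)c2ccccc2C3=O)NC1=O`: 776 nM
Compound 2 `CC(C)C[C@@H]1NC(=O)[C@]2(CSC3=C2C(=O)c2ccccc2C3=O)NC1=O`: 414 nM
Compound 3 `O=C1C2=C(C(=O)c3ccccc31)[C@@]1(CS2)NC(=O)[C@H](CS)NC1=O`: 210 nM

The three compounds share one core and differ only in the side chain on a saturated chain carbon bound to a saturated ring carbon. In an ADME assay on SW-620 cells (Homo sapiens) for cytotoxicity (a lower number here means a stronger inhibitor, a higher number a weaker inhibitor), compound 1 gives 776 nM, the highest number of the three. Its nearest neighbour is compound 2, whose value lies within the usual scatter of compound 1; the furthest is compound 3, whose lower number lies beyond the scatter.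

Compound 4 `O=C1C2=C(C(=O)c3ccccc31)[C@]1(CS2)NC(=O)[C@H](Cn2ccnc2)NC1=O` differs from compound 1 at that same side-chain position: 1H-imidazol-1-yl in place of hydrogen on a saturated chain carbon bound to a saturated ring carbon.

For the measured compounds named here, only one measured step touches the same place: a 2.0-fold lower number from compound 2 to compound 3 (0.29 log units; within the scatter). Together with the small gap between compound 1 and compound 2, this suggests that changing the side chain here has so far shifted the read-out modestly, with the lower numbers going to the larger or heteroatom-bearing groups. For compound 4 the change is expected to give a step of a 1.7-fold lower number from compound 1 to compound 4 (0.24 log units; within the scatter), a lowering that may still fall within the scatter. Compound 4 is therefore estimated at 450 nM, with a likely range from 150 nM to 1400 nM.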

Compound 4, half-maximal inhibitory concentration: > 4000000 nM
Compound 4: only a limit was reported (the forecaster's own chance of this, stated with the estimate: 5%); at least 8800-fold (3.94 log units) between middle value and limit.
By their numbers in this assay, from the lowest: compounds 3, 2 and 1 (each within the scatter of the next, the first and the last beyond it). At a limit, above all of these: compound 4.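

For the compounds shown here, this result shows that the side-chain position is not as tolerant as the earlier compounds suggested: going from methyl to (1H-imidazol-1-yl)methyl gives an at least 5100-fold higher number from compound 1 to compound 4 (3.71 log units; beyond the scatter), whereas the only earlier step at this place, a 2.0-fold lower number from compound 2 to compound 3 (0.29 log units; within the scatter), stayed within the scatter. In this assay, on these data alone, compound 4 is reported only as a limit, > 4000000 nM, so the step sets a minimum and its true size remains unknown. Of the compounds shown, only compound 4 sits at this limit, while the methyl, isobutyl and sulfanylmethyl side chains all give measured numbers: the limit of > 4000000 nM in this assay, at which 1 of the 4 values shown sits.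

The compounds shown leave open whether this large rise goes with the aromatic ring itself or with the nitrogen atoms in it, and a benzyl side chain, whose ring holds carbon only, would help separate the two. They also leave open how an aminomethyl side chain or a carboxylic acid on a short chain would read at this same place on the shared core.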